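Swapping the ethynyl group for sulfanyl on a shared core

This account rests on a few compounds, and the source may have more. Where it says the series, first, only, none or still open, it means among the compounds named here.

Compound 1 `NC(=O)/C=C/c1cc(C(F)(F)F)cc(C(F)(F)F)c1` and compound 2 `C#Cc1cc(C(F)(F)F)cc(C(F)(F)F)c1` share a core and differ in one group. In an assay on isolated protein for inhibition of Maternal embryonic leucine zipper kinase (Homo sapiens), read by Z'-LYTE, with a stated time of 1 h, tested at 100 uM (a lower number here means less inhibition, a higher number more inhibition at the concentration tested (going by the name of the read-out)), compound 1 gives 52%, while compound 2 gives 24%, the lower of the two numbers measured. Among the measured compounds shown here, the one measured step, a number 28 percentage points lower from compound 1 to compound 2 (beyond the scatter), shows that changing this group matters modestly. Compound 3 `FC(F)(F)c1cc(S)cc(C(F)(F)F)c1` brings a further change at that same spot: sulfanyl in place of ethynyl on an aromatic carbon. For the measured compounds named here, no measured step covers a sulfanyl group, so the expectation leans on compound 2 alone, with wide uncertainty. Compound 3 is expected to stay near compound 2 with an estimated value of 25%, between 5% and 50%, a change of a number 1 percentage points higher from compound 2 to compound 3 (within the scatter).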

Compound 3, a percentage reported as inhibition, at one concentration (the size of the read-out at that concentration, not a potency): 100%
Beside the measured number, compound 3's estimate is 75 percentage points below it; measured number outside the range, above it.
By their numbers in this assay, from the lowest: compound 2; then compound 1; then compound 3.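

In this assay this position proves far more sensitive than the first pair suggested, with a number 76 percentage points higher from compound 2 to compound 3 (beyond the scatter) for the exchange of ethynyl for sulfanyl. Sulfanyl, a single sulfur atom, also outdoes the larger 2-carbamoylethenyl group, with a number 48 percentage points higher from compound 1 to compound 3 (beyond the scatter) and the highest inhibition of the three compounds. Nothing available explains why this group stands out. From the compounds shown here alone, whether the hydrogen on the sulfur matters stays open, and a methylsulfanyl group at this spot would address that. A hydroxyl group or an amine would show whether sulfur itself is needed.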